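Extending the acrylamide chain on a shared thienopyrimidine scaffold

The source may report more compounds than this note shows. Statements on the series, on what has been measured and on what is new or still open speak of the compounds shown alone.

Three compounds share the same core and differ only in the unsaturated group on the carbonyl carbon of the amide. Compound 1 `C=CC(=O)Nc1cccc(Oc2nc(Nc3cccc(OC)c3)nc3ccsc23)c1` carries a vinyl group, compound 2 `COc1cccc(Nc2nc(Oc3cccc(NC(=O)C=C(C)C)c3)c3sccc3n2)c1` a 2-methylprop-1-en-1-yl group, and compound 3 `CC/C=C/C(=O)Nc1cccc(Oc2nc(Nc3cccc(OC)c3)nc3ccsc23)c1` a but-1-en-1-yl group. In a functional assay on MCF7 cells (Homo sapiens) for inhibition, read by MTT assay, with a stated time of 72 h (on this read-out lower numbers stand for stronger inhibition and higher numbers for weaker inhibition), compound 1 gives 19000 nM, compound 2 gives 35800 nM, and compound 3 gives 43400 nM, the highest of the three numbers. The step from the vinyl to the longer chain reads a 2.3-fold higher number from compound 1 to compound 3 (0.36 log units; beyond the scatter), while the step of a 1.2-fold higher number from compound 2 to compound 3 (0.08 log units; within the scatter) stays within the scatter.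

Compound 4 `CCC/C=C/C(=O)Nc1cccc(Oc2nc(Nc3cccc(OC)c3)nc3ccsc23)c1` takes the chain one carbon further: methyl in place of hydrogen on a saturated chain carbon, two bonds along the chain from a double-bonded chain carbon. For the measured compounds named here, the only step that bears on it is the chain lengthening a 2.3-fold higher number from compound 1 to compound 3 (0.36 log units; beyond the scatter), which raised the number modestly. A further small rise in this assay is therefore expected, though it may stay within the scatter. The expected step is a 1.3-fold higher number from compound 3 to compound 4 (0.10 log units; within the scatter). For compound 4 the estimate in this assay is 55000 nM, with a range from 25000 nM to 120000 nM.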

Compound 4, half-maximal inhibitory concentration: 5020 nM
Compound 4: middle estimate off by 11-fold (1.04 log units), on the high side; the whole stated range lies above it.
By their numbers in this assay, from the lowest: compound 4; then compounds 1, 2 and 3 (each within the scatter of the next, the first and the last beyond it).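

Adding one methyl on a saturated chain carbon, two bonds along the chain from a double-bonded chain carbon, reverses the direction of the earlier lengthening: this assay shows an 8.6-fold lower number from compound 3 to compound 4 (0.94 log units; beyond the scatter), whereas vinyl to but-1-en-1-yl gave a 2.3-fold higher number from compound 1 to compound 3 (0.36 log units; beyond the scatter). The pent-1-en-1-yl group also stands apart from the two other groups, with a 7.1-fold lower number from compound 2 to compound 4 (0.85 log units; beyond the scatter) and a 3.8-fold lower number from compound 1 to compound 4 (0.58 log units; beyond the scatter), so compound 4 is the strongest of the four, and at this position the number does not follow chain length in one steady direction. Nothing available here explains why this single added carbon has so large an effect.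

The compounds shown leave open whether the stronger inhibition continues, levels off or reverses with a longer chain such as hex-1-en-1-yl, and whether it depends on the chain's double bond, as a saturated pentyl chain in the same place would help to show. They also leave open whether a chain of similar length ending in an amine or a carboxylic acid would give a comparable number.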